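Moving the iodine on the phenyl ring of compound 3

The source may report more compounds than this note shows. Statements on the series, on what has been measured and on what is new or still open speak of the compounds shown alone.

Compound 1 `O=C(Nc1ccc(Br)cc1)N[C@H]1CC[C@H](Oc2ccc(F)cc2)CC1` gives > 20000 nM in a functional assay on CRL2813 cells (Homo sapiens) for cytotoxicity, read by sulforhodamine B assay, with a stated time of 5 days (a lower number here means a stronger inhibitor, a higher number a weaker inhibitor), which is a limit of the assay rather than a number.
Compound 2 `COc1ccccc1NC(=O)N[C@H]1CC[C@H](Oc2ccc(F)cc2)CC1` gives > 20000 nM in this assay, again only a limit.
Compound 3 `O=C(Nc1ccc(I)cc1)N[C@H]1CC[C@H](Oc2ccc(F)cc2)CC1` gives 10200 nM in this assay.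

Among the compounds with values here, compound 3 thus holds the only real number of the three, the other two resting at the limit of > 20000 nM in this assay, at which 2 of the 3 values shown sit. Compound 4 `O=C(Nc1ccccc1I)N[C@H]1CC[C@H](Oc2ccc(F)cc2)CC1` differs from compound 3 by 2-iodophenyl in place of 4-iodophenyl on an amide-type nitrogen. Within the data shown here, two measured steps bear on this change: an at least 1.9-fold lower number from compound 1 to compound 3 (0.29 log units; that floor lies within the scatter) and an at least 1.9-fold lower number from compound 2 to compound 3 (0.29 log units; that floor lies within the scatter), each a floor within the scatter, yet both favouring the 4-iodophenyl. Because an at least 1.9-fold lower number from compound 2 to compound 3 (0.29 log units; that floor lies within the scatter) ran against a 2-substituted phenyl, compound 4 is expected to come out weaker, a 1.8-fold higher number from compound 3 to compound 4 (0.25 log units; within the scatter). Compound 4 is estimated at 18000 nM, within 7000 nM to 40000 nM, with a fair chance of only a limit.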

Compound 4, half-maximal inhibitory concentration: > 20000 nM
Compound 4 gave a limit, no number (the forecaster's own chance of this, stated with the estimate: 50%); middle value at least 1.1-fold (0.04 log units) from the limit.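

With the same atoms joined differently, this pair isolates the place of the iodine: 2-iodophenyl in place of 4-iodophenyl gives an at least 1.9-fold higher number from compound 3 to compound 4 (0.29 log units; that floor lies within the scatter) in this assay. The steps linking compound 4 to compound 1 and compound 2 cannot be read, since each joins two limits. Compound 4 gives only a limit, leaving compound 3 with the sole real number: the limit of > 20000 nM in this assay, at which 3 of the 4 values shown sit.

As far as these compounds go, the actual number for compound 4 stays open. So does whether an amine or a carboxylic acid in place of the iodine would give a clearer reading at either place.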